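The compounds below may be only part of what the source reports. "The series", "measured", "known", "first", "only" and "open" are said of these compounds alone.

Working notes on the series. Compound 1 `c1ccc(-c2cnco2)c(NCC2=NCCN2)c1` and compound 2 `c1ccc(-c2ccccc2NCC2=NCCN2)nc1` share one core and differ only in the aromatic group on the aromatic carbon. In an assay for binding affinity to Alpha-1B adrenergic receptor (Homo sapiens) (on this read-out higher numbers stand for weaker inhibition and lower numbers for stronger inhibition), compound 1 gives 229 nM, and compound 2 gives 589 nM. For the measured compounds named here, compound 2 thus stands at the higher of the two numbers measured so far, its only neighbour being compound 1; the change is a 2.6-fold higher number from compound 1 to compound 2 (0.41 log units; beyond the scatter), a modest move to a weaker result.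

Compound 3 `c1cnc(-c2ccccc2NCC2=NCCN2)nc1` has not yet been measured in this assay. Its change is pyrimidin-2-yl in place of pyridin-2-yl on an aromatic carbon. Going by the values given here, the one measured step, with pyridin-2-yl in place of 1,3-oxazol-5-yl, is a change of a different kind and gives no direct guide to what a second ring nitrogen in a six-membered ring will do. Among the compounds with values here, with no bearing step in hand, the expected step from compound 2 to compound 3 in this assay is a 1.4-fold higher number from compound 2 to compound 3 (0.13 log units; within the scatter), a drift to a somewhat weaker number that could well fall within the scatter. Compound 3 is therefore estimated at 800 nM in this assay, with a range from 250 nM to 2500 nM.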

Compound 3, half-maximal inhibitory concentration: 2190 nM
Compound 3: the middle estimate sits 2.7-fold (0.44 log units) below what was measured; low and high end bracket the measured number.
By their numbers in this assay, from the lowest: compound 1; then compound 2; then compound 3.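

In this assay, this position on the aromatic carbon, ortho to a group of 7 heavy atoms, proves sensitive even to a change that keeps the ring six-membered and aromatic and the heavy-atom count at 6: pyrimidin-2-yl in place of pyridin-2-yl, with 2 ring hetero atoms instead of 1, gives a 3.7-fold higher number from compound 2 to compound 3 (0.57 log units; beyond the scatter). Measured against the 1,3-oxazol-5-yl group, the pyrimidin-2-yl group gives a 9.6-fold higher number from compound 1 to compound 3 (0.98 log units; beyond the scatter), so compound 3 is the weakest of the three, and the aromatic groups at this position now span a clear order from 1,3-oxazol-5-yl through pyridin-2-yl to pyrimidin-2-yl. No supporting data are available to explain this order.

The compounds shown leave open where a plain phenyl or a pyridin-3-yl group would fall in this order, and therefore whether the rise within the six-membered pair tracks the number of ring hetero atoms or something specific to pyrimidin-2-yl. They also leave open whether a methyl or an amine on the pyrimidin-2-yl ring would shift the number in this assay in either direction.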